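The source may report more compounds than this note shows. Statements on the series, on what has been measured and on what is new or still open speak of the compounds shown alone.

Compound 1 `Cc1oc(C(=O)O)cc1CCOc1ccc(-c2ccccc2)cc1`: 3800 nM
Compound 2 `Cc1oc(C(=O)NS(=O)(=O)c2ccccc2)cc1COc1ccc(-c2ccccc2)cc1`: 25 nM
Compound 3 `Cc1oc(CCC(=O)O)cc1COc1ccc(-c2ccccc2)cc1`: 80 nM

Of the compounds shown here, three sharing the same core have been measured in an assay on cells for displacement of a labelled ligand from prostaglandin E2 receptor EP4 subtype (Homo sapiens), read by scintillation counting; on this read-out lower numbers stand for stronger inhibition and higher numbers for weaker inhibition. Compound 2 gives the lowest number of the three. The nearest to it is compound 3, whose number is higher by a gap that lies beyond the usual scatter; the furthest is compound 1, whose number is higher still, again well beyond the scatter. No single-change step connects any two of these measured compounds, so their values can only be placed side by side, not traced to one structural cause.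

The step now followed goes from compound 2 to compound 4 `COc1ccc(-c2ccc(OCc3cc(C(=O)NS(=O)(=O)c4ccccc4)oc3C)cc2)cc1`, which is not yet measured in this assay. The change is methoxy in place of hydrogen on an aromatic carbon. It sits on an aromatic carbon of a six-membered aromatic ring of carbon only, para to a large group; cut one bond further out, it reads phenyl to 4-methoxyphenyl.

Within the data shown here, with no measured step of this kind to lean on, the expectation for this assay is a step of no more than the scatter in either direction, and the estimated step of a 1.3-fold lower number from compound 2 to compound 4 (0.10 log units; within the scatter) reflects that. Compound 4 is therefore expected to give about 20 nM, within a range from 6 nM to 70 nM.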

Compound 4, inhibition constant: 5 nM
Estimate against measurement, compound 4: 4.0-fold (0.60 log units) above; measured number outside the range, below it.
By their numbers in this assay, from the lowest: compound 4; then compound 2; then compound 3; then compound 1.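

In this assay the phenyl that becomes 4-methoxyphenyl proves to be a place where a small change registers: methoxy in place of hydrogen, on an aromatic carbon para to a large group, gives a 5.0-fold lower number from compound 2 to compound 4 (0.70 log units; beyond the scatter) and so moves the number beyond the scatter. The earlier compounds shown here could only be set side by side, whereas here a difference of 2 heavy atoms, one carbon and one oxygen, with no net charge, is tied directly to a measured step, and at this position the added group goes with a lower number rather than a higher one. Nothing measured on these compounds accounts for the size or direction of this step. 

The compounds shown leave open whether this step belongs to methoxy itself or would also appear with another group in the same place, such as a hydroxyl, a fluorine or an amine. They also leave open whether 4-methoxyphenyl would bring a step of like size to compound 3, which carries a carboxylic acid on a longer chain in place of the acyl sulfonamide of compound 2.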